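This account rests on a few compounds, and the source may have more. Where it says the series, first, only, none or still open, it means among the compounds named here.

Working notes on the series. Three analogues of the shared core have been run so far: compound 1 `CCCSc1nc(Cl)c2c(n1)N(Cc1ccccc1)C(C(=O)O)N2`, compound 2 `CCCSc1nc(Cl)c2c(n1)N(Cc1cccs1)C(C(=O)N1CCN(C)CC1)N2` and compound 3 `CCCSc1nc(Cl)c2c(n1)N(Cc1ccccc1)C(C(=O)Nc1ccccc1)N2`. In a functional assay on PC-3 cells (Homo sapiens) for antiproliferative activity, read by MTT assay, with a stated time of 72 h (on this read-out lower numbers stand for stronger inhibition and higher numbers for weaker inhibition), compound 1 gives 49200 nM. In this assay compound 2 gives 5020 nM, the lowest of the two numbers in hand, and the nearest other value is that of compound 1, which lies beyond the scatter from it. In this assay compound 3 returns only > 64000 nM, a limit of the assay and not a number, at the limit of > 64000 nM in this assay, at which 1 of the 3 values shown sits. Within the data shown here, the one step between neighbours that differ in a single place is an at least 1.3-fold higher number from compound 1 to compound 3 (0.11 log units; that floor lies within the scatter), and its floor sits inside the scatter.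

Compound 4 `CCCSc1nc(Cl)c2c(n1)N(Cc1ccco1)C(C(=O)N1CCN(C)CC1)N2` is not yet measured. It differs from compound 2 by furan-2-yl in place of thiophen-2-yl on a saturated chain carbon bound to a nitrogen on an aromatic ring in a ring. The measured step, an at least 1.3-fold higher number from compound 1 to compound 3 (0.11 log units; that floor lies within the scatter), concerns the substituent on the carbonyl carbon and leaves the group on the saturated chain carbon untouched, so it gives no direct guide to this change; the expectation therefore rests on compound 2 and its value 5020 nM. The step of a 1.2-fold higher number from compound 2 to compound 4 (0.08 log units; within the scatter) is expected to stay within the scatter, with no clear direction. For compound 4 the estimate is 6000 nM, within a range of 2500 nM to 15000 nM.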

Compound 4, half-maximal inhibitory concentration: 11400 nM
Compound 4: middle estimate off by 1.9-fold (0.28 log units), on the low side; measured number inside the range.
By their numbers in this assay, from the lowest: compound 2; then compound 4; then compound 1. At a limit, above all of these: compound 3.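

In this assay, furan-2-yl in place of thiophen-2-yl on a saturated chain carbon bound to a nitrogen on an aromatic ring in a ring gives a 2.3-fold higher number from compound 2 to compound 4 (0.36 log units; beyond the scatter). Among these compounds, this is the first single-place step that lies beyond the scatter, and it concerns a position that the earlier step left untouched: with the carbonyl substituent held fixed, exchanging sulfur for oxygen in a five-membered aromatic ring of equal heavy-atom count gives a modest but readable shift, with the lower number staying with the thiophen-2-yl group. No measured property in hand bears on why this exchange moves the number.

Going by these compounds, how a phenyl group at this position compares with thiophen-2-yl and furan-2-yl remains open, since compound 1 and compound 3 carry it only alongside other carbonyl substituents, and whether the step keeps its size with a different carbonyl substituent also remains open. Also unresolved is how a saturated ring such as cyclohexyl in that place, an amine in place of the chlorine, or a longer chain in place of the propyl group on sulfur would read.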